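Sulfonyl aryl exchange in a metabotropic glutamate receptor 5 series

A few compounds are considered here, and "the series" means these few. Any claim that something is new, unique, unknown or untested is made for them only; others in the source may bear on it.

Among the measured compounds shown here, compound 1 `COc1ccc(S(=O)(=O)c2cnc3cc(F)ccc3c2N2CCC(C)CC2)cc1` is one of two compounds measured in an assay on isolated protein for displacement of a labelled ligand from metabotropic glutamate receptor 5 (Homo sapiens), with a stated time of 60 min, tested at 1 uM (on this read-out higher numbers stand for more inhibition at the one concentration tested (going by the name of the read-out) and lower numbers for less inhibition), where compound 1 gives 90%. For the measured compounds named here, the only other number belongs to compound 2 `CC1CCN(c2c(S(=O)(=O)c3cc(F)cc(F)c3)cnc3ccc(Cl)cc23)CC1`, which in this assay gives 93%; the two values lie within the scatter of each other, so nothing separates them. Compound 3 `CC1CCN(c2c(S(=O)(=O)c3cc(F)cc(F)c3)cnc3cc(F)ccc23)CC1` keeps the core of compound 1 and carries the change (3,5-difluorophenyl in place of 4-methoxyphenyl on a sulfonyl sulfur). Going by the values given here, no pair of measured compounds shows this exchange on its own, so no measured step can be quoted for it. The expected step from compound 1 to compound 3 is a number 1 percentage points higher from compound 1 to compound 3 (within the scatter), which means none beyond the scatter, because compound 2 with the same sulfonyl aryl gives 93% and compound 1 gives 90%. For compound 3 the estimate in this assay is 91%, with a range from 80% to 98%.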

Compound 3, a percentage reported as inhibition, at one concentration (the size of the read-out at that concentration, not a potency): 77%
Beside the measured number, compound 3's estimate is 14 percentage points above it, outside the stated range (below it).
By their numbers in this assay, from the lowest: compound 3; then compounds 1 and 2 (each within the scatter of the next).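

In this assay, the group on the sulfonyl sulfur of the core of compound 1 is not interchangeable: 3,5-difluorophenyl in place of 4-methoxyphenyl gives a number 13 percentage points lower from compound 1 to compound 3 (beyond the scatter). This is the first single-place step in the series, so the earlier similarity of compound 1 and compound 2 could not have shown this sensitivity; it rests on one pair and describes only these two groups on this core. Nothing measured here accounts for the step.

As far as these compounds go, whether the drop follows the loss of 4-methoxyphenyl or the arrival of 3,5-difluorophenyl stays open, and unsubstituted phenyl or cyclohexyl on the sulfonyl sulfur would help to separate the two. Also open, from the compounds shown here alone, is whether the step persists as a difference in potency, as this read-out reflects a single concentration.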